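Swapping a cyano for a phenyl on a thiadiazole amide

The compounds below may be only part of what the source reports. "The series", "measured", "known", "first", "only" and "open" are said of these compounds alone.

Two compounds share a core and differ only in what sits on the outer benzene ring. Compound 1 `COc1cccc(OC)c1C(=O)Nc1nnc(-c2ccccc2)s1` carries hydrogen there, and in a functional assay on the whole organism (integument) for inhibition, with Chilo suppressalis as the target, read by scintillation counting, with a stated time of 72 h (a lower number here means a stronger inhibitor, a higher number a weaker inhibitor), compound 1 gives 2950 nM. Compound 2 `COc1cccc(OC)c1C(=O)Nc1nnc(-c2ccc(C#N)cc2)s1` carries a cyano group instead, and in this assay compound 2 gives 209 nM. The step of a 14-fold lower number from compound 1 to compound 2 (1.15 log units; beyond the scatter) is large, and compound 2 therefore stands as the stronger of the two measured compounds.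

Compound 3 `COc1cccc(OC)c1C(=O)Nc1nnc(-c2ccc(-c3ccccc3)cc2)s1` makes a further change at the same place: phenyl in place of cyano on an aromatic carbon. Within the data shown here, no measured pair shows this exact exchange, so the only guide is the step from compound 1 to compound 2, which tells that a small group at this position can matter a great deal, without saying what a phenyl will do. A phenyl is a far larger piece than a cyano and carries no acceptor, so the gain seen for compound 2 need not carry over. Compound 3 is expected to give 800 nM in this assay, within 150 nM to 4000 nM, an expected step of a 3.8-fold higher number from compound 2 to compound 3 (0.58 log units; beyond the scatter) toward a weaker inhibitor.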

Compound 3, half-maximal inhibitory concentration: 195 nM
The estimate for compound 3 lay 4.1-fold (0.61 log units) above the measured number, within the range that was stated.
By their numbers in this assay, from the lowest: compounds 3 and 2 (each within the scatter of the next); then compound 1.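

In this assay, the exchange of cyano for phenyl gives a 1.1-fold lower number from compound 2 to compound 3 (0.03 log units; within the scatter), so compound 2 and compound 3 cannot be told apart, although the phenyl brings 6 heavy atoms and 0 hydrogen-bond acceptors where the cyano had 2 heavy atoms and 1 hydrogen-bond acceptor. Phenyl in place of hydrogen gives a 15-fold lower number from compound 1 to compound 3 (1.18 log units; beyond the scatter), a large step that sets compound 3 alongside compound 2 and apart from compound 1, so among these three compounds the large step away from hydrogen does not depend on having a nitrile at this position. No measurement shown here explains why two such different groups give indistinguishable numbers.

On these data alone, with only hydrogen, cyano and phenyl at this position, it remains open whether an amine, a carboxylic acid or a longer alkyl chain would also match compound 2 and compound 3 or fall back toward compound 1. As far as these compounds go, it is equally open whether a chlorine or a methyl group added to the entering phenyl would shift the number or leave it within the scatter.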